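The compounds below may be only part of what the source reports. "The series", "measured", "known", "first", "only" and "open" are said of these compounds alone.

Measured compounds:
compound 1 `FC(F)(F)c1cccc(-c2nc3cnc(Nc4cnccn4)cc3[nH]2)c1`, 20%
compound 2 `Fc1ccc(-c2nc3cnc(Nc4cc(C(F)(F)F)ccn4)cc3[nH]2)cc1F`, 84%

In an ADME assay on microsomes from liver (Rattus norvegicus) for metabolic stability, read by LC-MS, with a stated time of 30 min, tested at 0.1 uM (on this read-out higher numbers stand for a more stable compound and lower numbers for a less stable compound), compound 2 gives 84%, the higher of the two numbers measured. The nearest compound is compound 1, which gives 20%, a gap that lies beyond the usual scatter; the two structures differ in more than one place, so the comparison only shows that the values stand far apart.

Compound 3 `Fc1ccnc(Nc2cc3[nH]c(-c4ccc(F)c(F)c4)nc3cn2)c1` differs from compound 2 in a single place: fluoro in place of trifluoromethyl on an aromatic carbon. Among the measured compounds shown here, no measured pair shows this change, so the size of its effect in this assay is open. The expected step from compound 2 to compound 3 is small and downward, a number 14 percentage points lower from compound 2 to compound 3 (beyond the scatter), possibly within the scatter. Compound 3 is expected to give 70%, with a range from 45% to 90%.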

Compound 3, percent of the compound remaining in the Rattus norvegicus assay: 66%
Compound 3: the middle estimate sits 4 percentage points above what was measured; low and high end bracket the measured number.
By their numbers in the Rattus norvegicus assay, from the lowest: compound 1; then compound 3; then compound 2.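

In the Rattus norvegicus assay, fluoro in place of trifluoromethyl opposite the ring nitrogen gives a number 18 percentage points lower from compound 2 to compound 3 (beyond the scatter). Among the compounds shown here, this is the first pair that differs in one place, so this gap, unlike the wider one seen earlier, can be tied to a single change, and the step is modest: compound 3 still gives 66%. In a physicochemical assay for solubility, using the shake flask method, in simulated intestinal fluid, measured as kinetic solubility, with a stated time of 20 h, at pH 6.5 (on this read-out lower numbers stand for lower solubility and higher numbers for higher solubility), compound 2 gives >= 50000 nM, which is a limit of the assay and not a number. In the physicochemical assay compound 3 gives >= 50000 nM, which is also a limit of the assay and not a number. In the physicochemical assay the step cannot be read, because both compounds sit at a limit of the assay and not at a number: the limit of >= 50000 nM in the physicochemical assay, at which 2 of the 2 values shown sit.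

One pair gives a single step, so it does not show how the read-out would respond to other groups at this place, such as a methyl group, a nitrile or an amine. As far as these compounds go, whether the same change gives a similar step with other groups on the rest of the molecule also stays open.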